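The source may report more compounds than this note shows. Statements on the series, on what has been measured and on what is new or still open speak of the compounds shown alone.

Values in an ADME assay on HEK293 cells (Homo sapiens) for cytotoxicity, read by resazurin assay, with a stated time of 48 h; a lower number here means that less compound is tolerated, a higher number that more compound is tolerated:
- Compound 1 `O=S(=O)(Nc1ccc(-c2nc3ccccc3o2)cc1)c1cccs1`: > 100000 nM (a limit)
- Compound 2 `COc1ccccc1S(=O)(=O)Nc1ccc(-c2nc3ccccc3o2)cc1`: > 100000 nM (a limit)
- Compound 3 `CCc1ccc(S(=O)(=O)Nc2ccc(-c3nc4ccccc4o3)cc2)cc1`: 82000 nM

Within the data shown here, compound 3, at 82000 nM, has the only actual number in this assay. The rest of the series stands at the limit of > 100000 nM in this assay, at which 2 of the 3 values shown sit. Compound 4 `O=S(=O)(Nc1ccc(-c2nc3ccccc3o2)cc1)c1ccc(F)cc1` carries fluoro in place of ethyl on an aromatic carbon, para to a large group: fluoro in place of ethyl on an aromatic carbon. Among the measured compounds shown here, two measured steps bear on this, each changing the group on the sulfonyl sulfur: an at least 1.2-fold lower number from compound 1 to compound 3 (0.08 log units; that floor lies within the scatter), and an at least 1.2-fold lower number from compound 2 to compound 3 (0.08 log units; that floor lies within the scatter). Neither floor exceeds the scatter, so the expected step is a 1.2-fold higher number from compound 3 to compound 4 (0.06 log units; within the scatter), with no change beyond the scatter. Compound 4 is estimated at 95000 nM, with an expected range of 45000 nM to 150000 nM.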

Compound 4, half-maximal cytotoxic concentration: > 100000 nM
Compound 4 ended at the assay's limit (the forecaster's own chance of this, stated with the estimate: 55%); middle value at least 1.0-fold (0.02 log units) away from the limit.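

In this assay, fluoro in place of ethyl at this position gives an at least 1.2-fold higher number from compound 3 to compound 4 (0.08 log units; that floor lies within the scatter), so only a floor for this change can be read, and that floor does not show an effect beyond the scatter. The steps joining compound 4 to compound 1 and to compound 2 cannot be read, as each links two limits. The series now gathers at a single limit: the limit of > 100000 nM in this assay, at which 3 of the 4 values shown sit.

From the compounds shown here alone, whether an amine, a carboxylic acid or a chain longer than ethyl at this position would give a clearly lower number remains open. So does how far past the limit compound 1, compound 2 and compound 4 truly lie.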